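The source may report more compounds than this note shows. Statements on the series, on what has been measured and on what is new or still open speak of the compounds shown alone.

Working notes on the series.

Among the measured compounds shown here, compound 2, `CCCCC#Cc1nc(NCc2cccc(I)c2)c2ncn([C@H]3[C@H](O)[C@H](O)[C@@H]4C[C@@H]43)c2n1`, is the higher of the two numbers measured so far in an assay on CHO cells for displacement of a labelled ligand from adenosine receptor A1 (Homo sapiens), read by scintillation counting, with a stated time of 60 min, tested at 10 uM; a higher number here means more inhibition at the concentration tested (going by the name of the read-out), a lower number less inhibition: compound 2 gives 48%. For the measured compounds named here, its only neighbour in the set, compound 1, `CCCCC#Cc1nc(NCc2cccc(Cl)c2)c2ncn([C@H]3[C@H](O)[C@H](O)[C@@H]4C[C@@H]43)c2n1`, gives 19% in this assay, and the single measured step, a number 29 percentage points higher from compound 1 to compound 2 (beyond the scatter), comes from iodo in place of chloro on an aromatic carbon.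

Compound 3, `CCCCC#Cc1nc(NCC)c2ncn([C@H]3[C@H](O)[C@H](O)[C@@H]4C[C@@H]43)c2n1`, has not been measured. It differs from compound 2 by methyl in place of 3-iodophenyl on a saturated chain carbon bound to a nitrogen on an aromatic ring. Going by the values given here, no measured step touches this change: the only step in hand swaps one halogen for another on the ring that is now removed, so it shows only that the ring and its substituent are not inert to the read-out, not what happens when the ring leaves. With the substituent whose change gave the larger number gone altogether, the expectation for compound 3 is a fall, a number 28 percentage points lower from compound 2 to compound 3 (beyond the scatter), with wide uncertainty. In this assay compound 3 is therefore estimated at 20%, in a range from 2% to 45%.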

Compound 3, a percentage reported as inhibition, at one concentration (the size of the read-out at that concentration, not a potency): 31%
Compound 3: middle estimate off by 11 percentage points, on the low side; measured number inside the range.
By their numbers in this assay, from the lowest: compound 1; then compound 3; then compound 2.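

Working from this assay, replacing the aromatic group with methyl at this position has no single direction: the 3-iodophenyl series gives a number 17 percentage points lower from compound 2 to compound 3 (beyond the scatter) while the 3-chlorophenyl series gives a number 12 percentage points higher from compound 1 to compound 3 (beyond the scatter) for the same kind of exchange. The sign of the step therefore depends on which halogen the departing ring carries, so the ring cannot be read as simply raising or lowering the number at this position. Compound 3 places the small ethylamino compound inside the interval set by the two halogenated compounds, with 3-iodobenzyl above it and 3-chlorobenzyl below it, and each gap is printed as beyond the scatter. No measurement available here accounts for this order.

The compounds shown leave open where an unsubstituted phenyl or a 3-bromophenyl would fall relative to the methyl, which would test whether the halogen sets the direction of the step. They also leave open how a longer chain such as propyl, or a hydroxyl or an amine at the end of the chain, would read at this same carbon.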